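Adding a Hydroxy Group to a Thiourea Sulfonamide

This account rests on a few compounds, and the source may have more. Where it says the series, first, only, none or still open, it means among the compounds named here.

Of the compounds shown here, three of a shared core have been tested in a functional assay on HL-60 cells (Homo sapiens) for inhibition, read by CCK-8 assay, with a stated time of 48 h; on this read-out lower numbers stand for stronger inhibition and higher numbers for weaker inhibition. Compound 1, with the structure `O=S(=O)(NCCNC(=S)Nc1cc(C(F)(F)F)cc(C(F)(F)F)c1)c1ccc(-c2ccccc2OCc2ccccc2)s1`, gives 2100 nM in this assay. Compound 2, with the structure `CC(C)c1ccc(Oc2ccc(O)c(O)c2)c(-c2ccsc2S(=O)(=O)NCCNC(=S)Nc2cc(C(F)(F)F)cc(C(F)(F)F)c2)c1`, gives 8200 nM, and compound 3, with the structure `O=S(=O)(NCCNC(=S)Nc1cc(C(F)(F)F)cc(C(F)(F)F)c1)c1cc(-c2ccccc2Oc2ccc(O)c(O)c2)cs1`, gives 600 nM. On these three numbers compound 1 stands second highest: compound 3 sits nearest with a lower number, and compound 2 sits furthest with a higher number, both gaps lying beyond the usual scatter.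

The unmeasured compound 4, with the structure `O=S(=O)(NCCNC(=S)Nc1cc(C(F)(F)F)cc(C(F)(F)F)c1)c1ccc(-c2ccccc2OCc2cccc(O)c2)s1`, differs from compound 1 in one place: hydroxy in place of hydrogen on an aromatic carbon. The change is a hydroxy entering on an aromatic carbon of a six-membered aromatic ring of carbon only, meta to a large group, so that the benzyloxy of compound 1 becomes (3-hydroxybenzyl)oxy.

Within the data shown here, no step between measured compounds shows what such a hydroxy does on this core. Compound 3, which carries hydroxy groups, gives the lowest of the three numbers, but its other differences from compound 1 are several, so nothing firm follows. The expected step of a 1.4-fold lower number from compound 1 to compound 4 (0.15 log units; within the scatter) is therefore small, toward a somewhat lower number, and may not exceed the scatter. Compound 4 is estimated at 1500 nM, within a range from 500 nM to 4500 nM.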

Compound 4, half-maximal inhibitory concentration: > 50000 nM
Compound 4: a limit, no number; the forecaster's own chance of this, stated with the estimate: 5%; middle value at least 33-fold (1.52 log units) from the limit.
By their numbers in this assay, from the lowest: compound 3; then compound 1; then compound 2. At a limit, above all of these: compound 4.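

In this assay, compound 4 gives > 50000 nM, which is a limit of the assay and not a number. Among these compounds, the single change of benzyloxy to (3-hydroxybenzyl)oxy gives an at least 23-fold higher number from compound 1 to compound 4 (1.37 log units; beyond the scatter), and this is the first step on the shared core that can be read between two compounds differing in one place. It shows that this position is far from indifferent to what it carries: one hydroxy on an aromatic carbon, meta to a large group, is enough to move the read-out beyond the scatter, and the full size of the step stays unknown, as the reading ends at a limit: the limit of > 50000 nM in this assay, at which 1 of the 4 values shown sits.

The compounds shown do not tell whether this loss belongs to the hydroxy itself or would come with any added group at this place, and a methoxy, a fluorine or an amine on the same carbon would help to separate those cases. They also leave open what a hydroxy would do on the other carbons of the same ring, and the values give no reason for the step.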